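Chloro for trifluoromethyl: notes on compound 3

The source may report more compounds than this note shows. Statements on the series, on what has been measured and on what is new or still open speak of the compounds shown alone.

Two compounds carry measurements in a functional assay on NCI/ADR-RES cells (Homo sapiens) for inhibition, read by sulforhodamine B assay, with a stated time of 48 h, tested at 0.1 uM; on this read-out lower numbers stand for a stronger effect and higher numbers for a weaker effect at the one concentration tested. Compound 1 `O=C(Nc1cccc(-n2cc(-c3ccncc3)c(-c3cc(O)cc(Cl)c3)n2)c1)Nc1ccc(Cl)c(Cl)c1` gives 105% in this assay. Compound 2 `COc1cc(Cl)cc(-c2nn(-c3cccc(NC(=O)Nc4ccc(Cl)c(C(F)(F)F)c4)c3)cc2-c2ccncc2)c1` gives 69% in this assay, the lower of the two numbers, and its gap to compound 1 lies beyond the scatter, so compound 2 shows the stronger effect at the concentration tested. Among the measured compounds shown here, no pair of measured compounds differs in a single place, so no measured step is at hand to calibrate the next change.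

Compound 3 `COc1cc(Cl)cc(-c2nn(-c3cccc(NC(=O)Nc4ccc(Cl)c(Cl)c4)c3)cc2-c2ccncc2)c1` is not yet measured. It differs from compound 2 in this way: chloro in place of trifluoromethyl on an aromatic carbon. For the measured compounds named here, with no measured step of the same kind to lean on, the expected step in this assay is small, plausibly within the scatter, with a slight lean toward a weaker effect, amounting to an expected a number 7 percentage points higher from compound 2 to compound 3 (within the scatter). Compound 3 is accordingly estimated at 76% in this assay, with a range from 56% to 96%.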

Compound 3, a percentage reported as activity, at one concentration (the size of the read-out at that concentration, not a potency): 98%
Compound 3: middle estimate off by 22 percentage points, on the low side; measured number outside the range, above it.
By their numbers in this assay, from the lowest: compound 2; then compounds 3 and 1 (each within the scatter of the next).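

In this assay, the change from 4-chloro-3-(trifluoromethyl)phenyl to 3,4-dichlorophenyl gives a number 29 percentage points higher from compound 2 to compound 3 (beyond the scatter), so this place, ortho to a chloro group and meta to a large group, responds to the swap, with trifluoromethyl giving the stronger effect at the one concentration tested. With the 3,4-dichlorophenyl group in place, methyl in place of hydrogen on an oxygen on an aromatic ring gives only a number 7 percentage points lower from compound 1 to compound 3 (within the scatter), so that change does not separate the two compounds. No measurement shown here offers a reason for the larger step.

From the compounds shown here alone, whether the oxygen change stays this small alongside trifluoromethyl remains open. So does how a nitrile or a methoxy group at the same place would read, and whether the step holds at other concentrations.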